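A few compounds are considered here, and "the series" means these few. Any claim that something is new, unique, unknown or untested is made for them only; others in the source may bear on it.

Measured so far:
compound 1, `Oc1ccccc1CNc1ccc(-c2ccc(F)cc2)cc1`: 3860 nM
compound 2, `Oc1ccccc1CNc1ccc(-c2ccc(Cl)cc2)cc1`: 2390 nM
compound 3, `Oc1ccccc1CNc1ccc(-c2cccc(F)c2)cc1`: 2020 nM

All three were tested in a functional assay on Jurkat cells (Homo sapiens) for activation, with a stated time of 24 h; a higher number here means that more compound is needed for the effect, a lower number that less compound is needed. The three numbers sit close together: the steps of a 1.6-fold lower number from compound 1 to compound 2 (0.21 log units; within the scatter), a 1.9-fold lower number from compound 1 to compound 3 (0.28 log units; within the scatter) and a 1.2-fold lower number from compound 2 to compound 3 (0.07 log units; within the scatter) all stay within the usual scatter of this assay, so none of the three can be singled out as the most active.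

Compound 4, `Oc1ccccc1CNc1ccc(-c2cccc(Cl)c2)cc1`, has not been measured yet. It differs from compound 3 in one place: chloro in place of fluoro on an aromatic carbon. The same kind of change links compound 1 to compound 2: chloro in place of fluoro on an aromatic carbon. In compound 1 the carbon carrying the halogen is para to a large group, while in compound 3 it is meta to a large group. The earlier exchange gave a 1.6-fold lower number from compound 1 to compound 2 (0.21 log units; within the scatter).

The cores of compound 1 and compound 3 differ by 3-fluorophenyl in place of 4-fluorophenyl on an aromatic carbon, and that difference gave a 1.9-fold lower number from compound 1 to compound 3 (0.28 log units; within the scatter).

For compound 4 a step of roughly the same size as the earlier one is expected, a 1.4-fold lower number from compound 3 to compound 4 (0.16 log units; within the scatter), because a 1.6-fold lower number from compound 1 to compound 2 (0.21 log units; within the scatter) was small and within the scatter. Compound 4 is therefore estimated at 1400 nM, most likely between 600 nM and 3200 nM.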

Compound 4, half-maximal effective concentration: 6200 nM
Compound 4: middle estimate off by 4.4-fold (0.65 log units), on the low side, and the stated range ends below it.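

In this assay, chloro in place of fluoro does not carry over cleanly from one core to the other: the same change on two cores in this assay, a 1.6-fold lower number (0.21 log units; within the scatter) from compound 1 to compound 2 and a 3.1-fold higher number (0.49 log units; beyond the scatter) from compound 3 to compound 4, 5.0-fold (0.70 log units) apart, beyond the scatter of two such steps. The new step, a 3.1-fold higher number from compound 3 to compound 4 (0.49 log units; beyond the scatter), therefore cannot be predicted from the earlier exchange, and a second step, a 2.6-fold higher number from compound 2 to compound 4 (0.41 log units; beyond the scatter), shows that 3-chlorophenyl and 4-chlorophenyl are also distinguishable here, whereas a 1.6-fold higher number from compound 1 to compound 4 (0.21 log units; within the scatter) does not separate that pair. This shows that the effect of the exchange depends on the core in this small set, but it rests on one pair per core, the earlier step alone does not establish a real change, and the numbers do not explain the difference or show how the exchange would behave on any other core.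

On these data alone, what a 3-bromophenyl or 3-methoxyphenyl group would give on the shared core stays open. So does whether an unsubstituted phenyl ring would sit closer to the fluoro or the chloro compounds.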